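Phenyl for trifluoromethyl on the amino-substituted ring

This account rests on a few compounds, and the source may have more. Where it says the series, first, only, none or still open, it means among the compounds named here.

Among the compounds with values here, in a functional assay on MOLT-4 cells (Homo sapiens) for inhibition, read by sulforhodamine B assay, with a stated time of 48 h, tested at 10 uM (a lower number here means less inhibition of growth, a higher number more inhibition of growth at the concentration tested), compound 2 (`C/C(=N/O)c1ccc(NC(=O)Cn2nc(C(F)(F)F)nc2N)cc1`) gives 23.3%, the lower of the two numbers available so far. Compound 1 (`COc1ccc(-c2nc3sc(-c4ccccc4)cn3n2)cc1`) gives 49%, a gap from compound 2 that lies beyond the usual scatter.

Compound 3 (`C/C(=N/O)c1ccc(NC(=O)Cn2nc(-c3ccccc3)nc2N)cc1`) differs from compound 2 in one place: phenyl in place of trifluoromethyl on an aromatic carbon. Within the data shown here, no measured pair shows this change, so the direction remains weakly supported. Compound 1 also carries phenyl but has a different core, and its 49% offers only a loose hint of an upward move. The expected step is a number 8.7 percentage points higher from compound 2 to compound 3 (within the scatter), upward and modest, and it may not exceed the scatter. For compound 3 the estimated value in this assay is 32%, with an expected range of 15% to 52%.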

Compound 3, percent growth inhibition at one concentration: 11.5%
Compound 3: middle estimate off by 20.5 percentage points, on the high side, outside the stated range (below it).
By their numbers in this assay, from the lowest: compound 3; then compound 2; then compound 1.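

On the aromatic carbon of the five-membered aromatic ring with 3 nitrogen, the change to phenyl now has a measured direction: in this assay, phenyl in place of trifluoromethyl gives a number 11.8 percentage points lower from compound 2 to compound 3 (beyond the scatter). On this core, then, phenyl at this carbon lowers growth inhibition at the concentration tested, and of the two groups trifluoromethyl gives the higher number. Nothing available accounts for the drop.

On these data alone, this reading rests on a single pair, so it remains open whether the step would hold on a different core. Also open, as far as these compounds go, is where other groups at this carbon, such as a methyl group, a primary amine or a carboxylic acid, would fall relative to trifluoromethyl and phenyl.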